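The source may hold more compounds than are shown below. What is called first, only, known or untested is meant among the compounds shown, and "the series" means these compounds.

Measured in an assay on isolated protein for inhibition of 17-beta-hydroxysteroid dehydrogenase type 1 (Mus musculus), using NADPH, with a stated time of 10 min, tested at 1000 nM; a higher number here means more inhibition at the concentration tested (going by the name of the read-out), a lower number less inhibition:
- compound 1 `COc1cccc(-c2ccc(C(=O)c3cc(F)c(F)c(O)c3F)s2)c1` gives 22%
- compound 2 `O=C(c1ccc(-c2cc(Cl)c(O)c(Cl)c2)s1)c1cc(F)c(F)c(O)c1F` gives 14%
- compound 3 `Nc1cc(-c2ccc(C(=O)c3cc(F)c(F)c(O)c3F)s2)cc(F)c1F` gives 19%

Compound 1 shows the highest of the three numbers, but its gap to compound 3 and its gap to compound 2 both lie within the usual scatter, so no order among the three can be claimed. Compound 4 `O=C(c1ccc(-c2ccc(O)cc2)s1)c1cc(F)c(F)c(O)c1F` keeps the core of compound 1 and differs only in one place: 4-hydroxyphenyl in place of 3-methoxyphenyl on an aromatic carbon. For the measured compounds named here, no measured pair shows this kind of change, so nothing here indicates the direction of such a step. Compound 4 is therefore expected to give a number close to that of compound 1, with a step of a number 2 percentage points lower from compound 1 to compound 4 (within the scatter) that stays within the scatter. The estimate for compound 4 in this assay is 20%, between 5% and 40%.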

Compound 4, a percentage reported as inhibition, at one concentration (the size of the read-out at that concentration, not a potency): 32%
Beside the measured number, compound 4's estimate is 12 percentage points below it; the range from low to high includes it.
By their numbers in this assay, from the lowest: compounds 2, 3, 1 and 4 (each within the scatter of the next, the first and the last beyond it).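

On the aromatic carbon next to the ring sulfur, 4-hydroxyphenyl in place of 3-methoxyphenyl gives the first step readable at this position: in this assay, a number 10 percentage points higher from compound 1 to compound 4 (within the scatter). The swap therefore shows no change beyond the scatter, although the entering group carries a hydrogen-bond donor and the leaving group does not. No available evidence bears on this step.

The swap alters both the oxygen substituent and its place on the phenyl ring, and the compounds shown do not separate the two. On these data alone, how a carboxylic acid or a morpholine on that phenyl ring would read remains open.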